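The source may report more compounds than this note shows. Statements on the series, on what has been measured and on what is new or still open speak of the compounds shown alone.

Compound 1 `Cc1ccc(CS/C(=C/c2ccc(O)cc2)C(=O)c2ccc(Cl)cc2)cc1`: 10000 nM
Compound 2 `Cc1ccc(CS/C(=C/c2sccc2C)C(=O)c2ccc(Cl)cc2)cc1`: 10000 nM

These numbers come from a functional assay on DU-145 cells (Homo sapiens) for inhibition, read by trypan blue exclusion, with a stated time of 96 h (a lower number here means a stronger inhibitor of growth, a higher number a weaker inhibitor of growth), where compound 2 stands level with compound 1. The next analogue, compound 3 `Cc1ccc(CS/C(=C/c2cc(Cl)cc(Cl)c2)C(=O)c2ccc(Cl)cc2)cc1`, keeps the shared core and changes one group, with 3,5-dichlorophenyl in place of 3-methylthiophen-2-yl on a double-bonded chain carbon bound to a double-bonded chain carbon. For the measured compounds named here, only one measured step concerns this same place: no change at the digits printed from compound 1 to compound 2 (within the scatter). That step swapped one aromatic group for a quite different one, and the value stayed within the scatter. Going by the values given here, it is a single step, however, and no measured compound carries 3,5-dichlorophenyl, so the evidence is thin. No shift beyond the scatter is therefore expected, although a slightly stronger result would not be surprising. The expected step is a 1.3-fold lower number from compound 2 to compound 3 (0.10 log units; within the scatter). For compound 3 the estimated value is 8000 nM, with an expected range of 3000 nM to 15000 nM.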

Compound 3, concentration for 50% growth inhibition: 10000 nM
The estimate for compound 3 lay 1.3-fold (0.10 log units) below the measured number, and the stated range covers the measured number.
By their numbers in this assay, from the lowest: compounds 1, 2 and 3 (each within the scatter of the next).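

In this assay, 3,5-dichlorophenyl in place of 3-methylthiophen-2-yl gives no change at the digits printed from compound 2 to compound 3 (within the scatter) and, set against 4-hydroxyphenyl, gives no change at the digits printed from compound 1 to compound 3 (within the scatter) at this same place on a double-bonded chain carbon. A five-membered aromatic ring with sulfur and two different six-membered aromatic rings now print the same number, so the earlier single swap is no longer the only sign that exchanging one aromatic group for another here leaves growth inhibition unchanged. Nothing among the data given explains this flat result.

Whether any group at this place can lower the number stays open, as an amine, a carboxylic acid or a longer chain stands in none of these compounds. Nor do they show what a change elsewhere on the shared core would do.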